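The compounds below may be only part of what the source reports. "The series", "measured", "known", "first", "only" and "open" are said of these compounds alone.

Going by the values given here, in a functional assay on HepG2 cells (Homo sapiens) for inhibition, read by MTT assay, with a stated time of 24 h (on this read-out lower numbers stand for stronger inhibition of growth and higher numbers for weaker inhibition of growth), three compounds have numbers so far. Compound 3 (`COc1ccc(C(=O)n2c(-c3cn(C)c4ccc(OC)cc34)nc3ccccc32)cc1`) gives 12800 nM and compound 2 (`COc1ccc2c(c1)c(-c1nc3ccccc3n1C(=O)c1ccccc1OC)cn2C`) gives 23600 nM, a gap within the scatter, so the two share the low end of this small set. Compound 1 (`Cn1cc(-c2nc3ccccc3n2C(=O)c2ccccc2Br)c2ccccc21`) gives 68200 nM, a higher number that lies beyond the scatter from compound 3.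

Compound 4 (`COc1ccc2c(c1)c(-c1nc3ccccc3n1C(=O)c1ccccc1Br)cn2C`) keeps the core of compound 3 and changes one group: 2-bromophenyl in place of 4-methoxyphenyl on a carbonyl carbon. The only measured step at this place is a 1.8-fold lower number from compound 2 to compound 3 (0.27 log units; within the scatter), so moving the methoxy group around that ring has shown no clear change. Among the compounds with values here, no measured pair tests the 2-bromophenyl group on this core. Within the data shown here, the one compound that carries it, compound 1 at 68200 nM, has a different core and a higher number, which tilts the expectation upward. A modest rise, close to the edge of the scatter, therefore seems likely, and the estimated step is a 1.9-fold higher number from compound 3 to compound 4 (0.27 log units; within the scatter). The expected value for compound 4 is 24000 nM, within a range from 10000 nM to 55000 nM.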

Compound 4, concentration for 50% growth inhibition: 54200 nM
Compound 4: the middle estimate sits 2.3-fold (0.35 log units) below what was measured, within the range that was stated.
By their numbers in this assay, from the lowest: compounds 3 and 2 (each within the scatter of the next); then compounds 4 and 1 (each within the scatter of the next).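

In this assay the 2-bromophenyl group now has a direct comparison on the core of compound 3, and it gives a 4.2-fold higher number from compound 3 to compound 4 (0.63 log units; beyond the scatter), whereas the two methoxy-bearing compounds gave only a 1.8-fold lower number from compound 2 to compound 3 (0.27 log units; within the scatter). Bromo in place of methoxy on an aromatic carbon also raises the number, with a 2.3-fold higher number from compound 2 to compound 4 (0.36 log units; beyond the scatter), so on this core the bromo compound is the weaker in both comparisons. Methoxy in place of hydrogen on an aromatic carbon, with the 2-bromophenyl group kept, gives a 1.3-fold lower number from compound 1 to compound 4 (0.10 log units; within the scatter), so that change on the core shows no clear effect here.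

Nothing available here explains why these numbers move. As far as these compounds go, it also remains open how this core would respond to an amine or a carboxylic acid on the phenyl ring in place of bromo or methoxy.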